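A few compounds are considered here, and "the series" means these few. Any claim that something is new, unique, unknown or untested is made for them only; others in the source may bear on it.

Measured compounds in a functional assay on cells (T-cell, Homo sapiens) for inhibition; on this read-out lower numbers stand for stronger inhibition and higher numbers for weaker inhibition:
Compound 1 `COc1ccc(-c2cnc3nc(N)nc(N4CCN(C(=O)Nc5ccc(C)cc5)CC4)c3n2)cc1OC`: compound 1 gives 0.8 nM
Compound 2 `COc1ccc(-c2cnc3nc(N)nc(N4CCN(Cc5c(Cl)cccc5Cl)CC4)c3n2)cc1OC`: compound 2 gives 7600 nM

Compound 2 stands highest of the two numbers measured in this assay; the nearest is compound 1, and the measured step of a 9500-fold higher number from compound 1 to compound 2 (3.98 log units; beyond the scatter) is large and beyond the scatter.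

Compound 3 `COc1ccc(-c2cnc3nc(N)nc(N4CCN(Cc5ccccc5)CC4)c3n2)cc1OC` is unmeasured. The change from compound 2 is phenyl in place of 2,6-dichlorophenyl on a saturated chain carbon bound to an amine nitrogen in a ring. Going by the values given here, no measured step follows this change: the only step in the set, a 9500-fold higher number from compound 1 to compound 2 (3.98 log units; beyond the scatter), replaces a carbamoyl group on the ring nitrogen by the dichlorobenzyl group and says nothing about the chlorines themselves. The expectation therefore rests on compound 2 alone, with a wide range. Compound 3 is expected to stay near compound 2, with the step of a 1.3-fold lower number from compound 2 to compound 3 (0.10 log units; within the scatter) in this assay not clearly beyond the scatter in either direction. The estimate for compound 3 in this assay is 6000 nM, between 1200 nM and 30000 nM.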

Compound 3, half-maximal inhibitory concentration: 900 nM
For compound 3 the middle estimate is 6.7-fold (0.82 log units) above the measured one, outside the stated range (below it).
By their numbers in this assay, from the lowest: compound 1; then compound 3; then compound 2.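

In this assay, going from 2,6-dichlorobenzyl to benzyl gives an 8.4-fold lower number from compound 2 to compound 3 (0.93 log units; beyond the scatter) on a saturated chain carbon bound to an amine nitrogen in a ring, so the chlorines on this group themselves move the read-out, which the earlier carbamoyl-to-dichlorobenzyl step could not separate. Benzyl still stays far from the carbamoyl compound, with a 1100-fold higher number from compound 1 to compound 3 (3.05 log units; beyond the scatter) for the change on the ring nitrogen, so most of the earlier gap remains without the chlorines. No evidence at hand accounts for either step.

Still open, going by these compounds, is whether a single chlorine on the benzyl group gives a number nearer compound 3 or compound 2. Also open, on these data alone, is which part of (4-methylphenyl)carbamoyl carries the low number, for instance whether phenylcarbamoyl or acetyl on the same ring nitrogen would hold it.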